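Cytotoxicity notes on a pyrazole amine series

The compounds below may be only part of what the source reports. "The series", "measured", "known", "first", "only" and "open" are said of these compounds alone.

The series is tested in an ADME assay on Huh-7 cells (Homo sapiens) for cytotoxicity; on this read-out lower numbers stand for higher toxicity in this test and higher numbers for lower toxicity in this test. Compound 1 `Cc1ccccc1CNc1nn(-c2ccc(F)cc2F)cc1CNCCN1CCN(C)CC1` gives > 20000 nM in this assay, which is a limit of the assay and not a number. Compound 2 `Cc1c(CNCCN2CCN(C)CC2)c(-c2ccccc2)nn1-c1ccc(F)cc1` likewise gives > 20000 nM in this assay, again a limit rather than a number. Compound 3 `CCCN1CCC(CNCc2cn(-c3ccc(C(F)(F)F)cc3)nc2-c2ccc(C(F)(F)F)cc2)CC1` gives 1200 nM in this assay. Compound 1 thus stands at the limit of > 20000 nM in this assay, at which 2 of the 3 values shown sit, and only compound 3 returns a measured value.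

Compound 4 `COc1ccc(-c2nn(-c3ccc(F)cc3F)cc2CNCCN2CCN(C)CC2)cc1` is to be measured in this assay. It differs from compound 1 by 4-methoxyphenyl in place of (2-methylbenzyl)amino on an aromatic carbon. Going by the values given here, compound 2 carries a six-membered aromatic carbon ring on the same side of the shared core and also sits at the limit, while compound 3, with two trifluoromethyl-bearing rings and a propylpiperidine, is the only one with a number.

For compound 4 the expectation is no step beyond the scatter, a step that the limit leaves unreadable from compound 1 to compound 4, with the measurement most likely returning a limit again. Compound 4 is estimated at 25000 nM, in the range 8000 nM to 70000 nM.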

Compound 4, half-maximal cytotoxic concentration: > 20000 nM
Compound 4 was reported as a limit (the forecaster's own chance of this, stated with the estimate: 70%); the middle value does not contradict the limit.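

In this assay compound 4 gives > 20000 nM as a limit of the assay and not a number. Compound 1 also sits at a limit, so no step can be read between compound 1 and compound 4. The compounds shown leave open whether 4-methoxyphenyl in place of (2-methylbenzyl)amino changes the value in this assay at all.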